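This account rests on a few compounds, and the source may have more. Where it says the series, first, only, none or still open, it means among the compounds named here.

Measured compounds:
Compound 1 `COc1cc(C)cc(-c2c(-c3ccnc(-c4ccc(C(C)=O)cc4)c3)cnn2CC#N)c1`, giving 100%
Compound 2 `COc1cc(C)cc(-c2nn(CC#N)cc2-c2ccc(-c3cccc(C(C)=O)c3)nc2)c1`, giving 101%
Compound 3 `COc1cc(C)cc(-c2nn(CC#N)cc2-c2ccnc(-c3ccc(N(C)C)cc3)c2)c1`, giving 103%

These three were tested in a functional assay on MDA-MB-435 cells (Homo sapiens) for cytotoxicity, read by sulforhodamine B assay, with a stated time of 48 h, tested at 0.001 uM; on this read-out higher numbers stand for a weaker effect at the one concentration tested and lower numbers for a stronger effect. Compound 1 gives 100%, which is the lowest of the three numbers, yet compound 2 with 101% and compound 3 with 103% both lie within the usual scatter of it, so no real difference among the three can be read. No pair of these compounds differs in a single place, so no step between measured compounds is available.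

Compound 4 `COc1cc(C)cc(-c2c(-c3ccnc(-c4ccc(N(C)C)cc4)c3)cnn2CC#N)c1` has not yet been measured in this assay. It differs from compound 1 as follows: dimethylamino in place of acetyl on an aromatic carbon. Compound 3 carries a dimethylamino group too and gives 103%, close to compound 1, so a dimethylamino in place of acetyl is not expected to move the read-out beyond the scatter. The step from compound 1 to compound 4 is estimated as a number 2 percentage points higher from compound 1 to compound 4 (within the scatter), that is, none beyond the scatter. Compound 4 is therefore expected to give about 102%, within a range from 93% to 111%.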

Compound 4, a percentage reported as activity, at one concentration (the size of the read-out at that concentration, not a potency): 88%
Beside the measured number, compound 4's estimate is 14 percentage points above it, and the stated range ends above it.
By their numbers in this assay, from the lowest: compound 4; then compounds 1, 2 and 3 (each within the scatter of the next).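

In this assay, replacing 4-acetylphenyl with 4-(dimethylamino)phenyl gives a number 12 percentage points lower from compound 1 to compound 4 (beyond the scatter), the first step in one place among these compounds, so the group on this aromatic carbon, para to a large group, does bear on the read-out. Acetyl and dimethylamino have the same counts of heavy atoms, hydrogen-bond donors and hydrogen-bond acceptors, and neither carries a net charge, so these counts do not separate the two groups. Nothing measured here bears on the reason for the step.

The compounds shown leave open whether a primary amine, a methoxy group or a carboxylic acid at this place would lower the number further, or raise it. They also leave open whether the step holds at other concentrations or on a different core.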